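Cytotoxicity notes: chloro in place of methoxy

A few compounds are considered here, and "the series" means these few. Any claim that something is new, unique, unknown or untested is made for them only; others in the source may bear on it.

Measured so far:
compound 1, `COc1ccc(-c2cs/c(=N\NC(=O)c3ccc(O)cc3)n2-c2ccc(OC)cc2OC)cc1`: 95500 nM
compound 2, `O=C(c1ccc(O)cc1)n1nc(-c2c(Cl)cccc2Cl)sc1=S`: 67600 nM
compound 3, `Cc1ccc(-c2cs/c(=N\NC(=O)c3ccc(O)cc3)n2-c2c(C)cccc2C)cc1`: the value < 100000 nM is a limit of the assay, not a number.

In a functional assay on OVCAR-3 cells (Homo sapiens) for cytotoxicity, read by sulforhodamine B assay, with a stated time of 48 h (a higher number here means that more compound is tolerated, a lower number that less compound is tolerated), compound 1 holds the higher of the two numbers, though the gap to compound 2 sits within the scatter. The remaining value is the limit of < 100000 nM in this assay, at which 1 of the 3 values shown sits. Within the data shown here, no pair of measured compounds differs in one place, so no measured step exists. Compound 4, `COc1ccc(-n2c(-c3ccc(Cl)cc3)cs/c2=N\NC(=O)c2ccc(O)cc2)c(OC)c1`, carries chloro in place of methoxy on an aromatic carbon. Among the measured compounds shown here, with all numbers clustered at weak cytotoxicity and no step to lean on, the change from compound 1 to compound 4 is expected to stay within the scatter in this assay; the step of a 1.1-fold lower number from compound 1 to compound 4 (0.05 log units; within the scatter) is estimated as small in either direction. Compound 4 is expected at 85000 nM, between 40000 nM and 180000 nM.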

Compound 4, concentration lethal to 50% of the cells: < 100000 nM
Compound 4: only a limit was reported; the forecaster's own chance of this, stated with the estimate: 40%; the middle value does not contradict the limit.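

In this assay compound 4 gives < 100000 nM, a limit and not a number. No step from compound 1 to compound 4 can be read, because the result is a limit: the limit of < 100000 nM in this assay, at which 2 of the 4 values shown sit.
From the compounds shown here alone, whether chloro in place of methoxy on an aromatic carbon changes the number at all stays open.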